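Pyrazole Chalcones on M14 Cells: Dichlorophenyl Replaces Aminophenyl

This account rests on a few compounds, and the source may have more. Where it says the series, first, only, none or still open, it means among the compounds named here.

Compound 1 `COc1ccc(-c2cc(/C=C/C(=O)c3ccc(N)cc3)[nH]n2)cc1`: -71%
Compound 2 `COc1cc(-c2cc(/C=C/C(=O)c3ccc(N)cc3)[nH]n2)cc(OC)c1OC`: -78%

Of the compounds shown here, two have been measured in a functional assay on M14 cells (Homo sapiens) for cytotoxicity, read by sulforhodamine B assay, with a stated time of 48 h, tested at 100 uM; on this read-out higher numbers stand for a weaker effect at the one concentration tested and lower numbers for a stronger effect. In this assay compound 2 `COc1cc(-c2cc(/C=C/C(=O)c3ccc(N)cc3)[nH]n2)cc(OC)c1OC` gives -78%, the lowest of the two numbers; compound 1 lies a few points higher, within the scatter, so the two cannot be ordered.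

Compound 3 `COc1cc(-c2cc(/C=C/C(=O)c3ccc(Cl)c(Cl)c3)[nH]n2)cc(OC)c1OC` is not yet measured. It differs from compound 2 by 3,4-dichlorophenyl in place of 4-aminophenyl on a carbonyl carbon. For the measured compounds named here, no step between measured compounds bears on this change, so the expectation rests on compound 2 alone. A step of a number 8 percentage points higher from compound 2 to compound 3 (within the scatter) is expected, none beyond the scatter in either direction. Compound 3 is estimated at -70%, in the range -95% to -35%.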

Compound 3, a percentage reported as activity, at one concentration (the size of the read-out at that concentration, not a potency): 20%
Estimate against measurement, compound 3: 90 percentage points below; measured number outside the range, above it.
By their numbers in this assay, from the lowest: compounds 2 and 1 (each within the scatter of the next); then compound 3.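

In this assay, the group on the carbonyl carbon turns out to weigh heavily: 3,4-dichlorophenyl in place of 4-aminophenyl gives a number 98 percentage points higher from compound 2 to compound 3 (beyond the scatter) and so a far weaker effect. Compound 1 and compound 2 both carry 4-aminophenyl there, so they could not show this sensitivity. Nothing available accounts for the loss. On these data alone, whether a phenyl ring bearing a hydroxyl or a dimethylamino group would keep the effect seen with 4-aminophenyl remains open. So does whether 3,4-dichlorophenyl would cost as much on the core of compound 1.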